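The source may hold more compounds than are shown below. What is called first, only, known or untested is meant among the compounds shown, and "the series" means these compounds.

Compound 2, with structure `COc1ccc(C(=O)N(C)c2ccc3[nH]c(-c4n[nH]c5ccccc45)cc3n2)cc1`, is the weaker of the two measured compounds here: in a functional assay on SMMC-7721 cells (Homo sapiens) for antiproliferative activity, read by MTT assay, with a stated time of 72 h (on this read-out higher numbers stand for weaker inhibition and lower numbers for stronger inhibition), compound 2 gives 23700 nM, the highest of the two numbers. Its nearest neighbour is compound 1, with structure `CN(C(=O)c1ccc(F)cc1)c1ccc2[nH]c(-c3n[nH]c4ccccc34)cc2n1`, which in this assay gives 9150 nM. Going by the values given here, the single measured step, a 2.6-fold higher number from compound 1 to compound 2 (0.41 log units; beyond the scatter), comes from putting methoxy in place of fluoro on an aromatic carbon, and its size is modest.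

Compound 3, with structure `CN(C(=O)c1ccc([N+](=O)[O-])cc1)c1ccc2[nH]c(-c3n[nH]c4ccccc34)cc2n1`, differs from compound 2 by nitro in place of methoxy on an aromatic carbon; the new group sits on an aromatic carbon of a six-membered aromatic ring of carbon only, para to a large group, so the change is again a swap at the same place on the same ring. Among the compounds with values here, only that one step bears on this swap, and it concerns a different pair of groups, so it serves as a guide to the size of such swaps rather than to their direction. A modest step is therefore expected, in either direction, and the estimate for compound 3 is placed a little toward the number of compound 1, so that the expected step of a 2.0-fold lower number from compound 2 to compound 3 (0.30 log units; within the scatter) is small. On that basis compound 3 is estimated at 12000 nM, within a range from 4000 nM to 36000 nM.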

Compound 3, half-maximal inhibitory concentration: 18400 nM
Compound 3: middle estimate off by 1.5-fold (0.19 log units), on the low side, within the range that was stated.
By their numbers in this assay, from the lowest: compounds 1, 3 and 2 (each within the scatter of the next, the first and the last beyond it).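

Putting nitro on this aromatic carbon, para to a large group, gives a 1.3-fold lower number from compound 2 to compound 3 (0.11 log units; within the scatter) in this assay, and the comparison with the other earlier compound gives a 2.0-fold higher number from compound 1 to compound 3 (0.30 log units; within the scatter). Nitro therefore cannot be told apart from either methoxy or fluoro in this assay, even though those two groups are separated from each other by a 2.6-fold higher number from compound 1 to compound 2 (0.41 log units; beyond the scatter), the only one of the three steps that lies beyond the scatter. Compound 3 adds a third group at this place without widening the spread of numbers, and no separate measurement is available to explain why these three groups give such similar results.

It remains open whether a very different group on this same carbon, such as an amine, a carboxylic acid or a longer chain, would move the number well beyond the scatter, and how plain hydrogen would compare with the three groups shown. On these data alone, all three compounds carry their group in the same place on the same ring, so the effect of these groups elsewhere on that ring, or of any change to the shared core, also remains unknown.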